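The source may report more compounds than this note shows. Statements on the series, on what has been measured and on what is new or still open speak of the compounds shown alone.

Measured compounds in a functional assay on NCI-H1975 cells (Homo sapiens) for inhibition, read by sulforhodamine B assay, tested at 10 uM; on this read-out higher numbers stand for more inhibition at the one concentration tested (going by the name of the read-out) and lower numbers for less inhibition:
- compound 1 `CN1CCN(c2ccc(C3=NNC(c4ccc(N(C)C)cc4)C3)cc2)CC1`: 2.4%
- compound 2 `COC(=O)CC(=O)N1N=C(c2ccc(N3CCN(C)CC3)cc2)CC1c1ccc(N(C)C)cc1`: -2.2%
- compound 3 `CN1CCN(c2ccc(C3=NN(S(=O)(=O)C4CC4)C(c4ccc(N(C)C)cc4)C3)cc2)CC1`: 0.2%

All three compounds share one core and differ only at an amine nitrogen in a ring. Compound 2 gives the lowest of the three numbers in this assay, but its steps to the others are small: a number 4.6 percentage points lower from compound 1 to compound 2 (within the scatter) and a number 2.4 percentage points higher from compound 2 to compound 3 (within the scatter), both within the scatter, and likewise a number 2.2 percentage points lower from compound 1 to compound 3 (within the scatter). In plain terms, none of the three shows meaningful inhibition at the tested concentration.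

Compound 4 `COC(=O)CC(=O)N1N=C(c2ccc(-n3cncn3)cc2)CC1c1ccc(N(C)C)cc1` has not yet been measured. It differs from compound 2 in a different place: 1H-1,2,4-triazol-1-yl in place of 4-methylpiperazin-1-yl on an aromatic carbon. Among the compounds with values here, no measured step touches this position, so the three steps known here say nothing direct about it; they only show that changes at the amine nitrogen in a ring leave the read-out near zero. With no evidence for a change beyond the scatter, compound 4 is expected to stay close to compound 2, with a step of about a number 3.2 percentage points higher from compound 2 to compound 4 (within the scatter). The estimate for compound 4 in this assay is 1%, with a range from -12% to 15%.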

Compound 4, a percentage reported as inhibition, at one concentration (the size of the read-out at that concentration, not a potency): 1.5%
Estimate against measurement, compound 4: 0.5 percentage points below; measured number inside the range.
By their numbers in this assay, from the lowest: compounds 2, 3, 4 and 1 (each within the scatter of the next).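

In this assay, within the data shown here, the first change at this aromatic carbon gives a number 3.7 percentage points higher from compound 2 to compound 4 (within the scatter). The earlier compounds shown here varied only the amine nitrogen in a ring, and this pair adds that the read-out also stays near zero when 1H-1,2,4-triazol-1-yl, a five-membered aromatic ring, stands in place of 4-methylpiperazin-1-yl, a six-membered non-aromatic ring. Nothing available explains this outcome.

On these data alone, because this position rests on one pair, it remains open whether a quite different group on the same aromatic carbon, such as a carboxylic acid or an amine on a longer chain, would lift the number beyond the scatter. Also open, as far as these compounds go, is whether any change at this position would matter alongside a different group on the amine nitrogen in a ring.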